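The source may report more compounds than this note shows. Statements on the series, on what has been measured and on what is new or still open speak of the compounds shown alone.

In a functional assay on T47D cells (Homo sapiens) for inhibition (on this read-out higher numbers stand for weaker inhibition and lower numbers for stronger inhibition), compound 1 `Oc1cccc(-c2cc(-c3ccccc3F)cc(-c3ccccc3O)n2)c1` gives 24200 nM, and compound 3 `Oc1ccc(-c2cc(-c3ccccc3F)cc(-c3ccc(O)cc3)n2)cc1` gives 15100 nM. Compound 2 `Oc1ccc(-c2cc(-c3ccccc3F)cc(-c3ccccc3O)n2)cc1` reaches only > 50000 nM in this assay, which is a limit of the assay and not a number. The steps of an at least 2.0-fold higher number from compound 1 to compound 2 (0.31 log units; beyond the scatter) and an at least 3.3-fold lower number from compound 2 to compound 3 (0.51 log units; beyond the scatter) each move a hydroxyphenyl group on the shared core. Compound 4 `Oc1ccc(-c2cc(-c3ccc(C(F)(F)F)cc3)cc(-c3ccccc3O)n2)cc1` arises from compound 2 by 4-(trifluoromethyl)phenyl in place of 2-fluorophenyl on an aromatic carbon. Going by the values given here, none of the measured steps touches the 2-fluorophenyl group, so no measured step bears on this change, and no shift beyond the scatter is expected in this assay in either direction. Compound 4 is therefore expected to stay near the limit, with an estimated 50000 nM, between 15000 nM and 150000 nM. The expected step is a number no higher from compound 2 to compound 4 (the limit leaves the size open).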

Compound 4, half-maximal inhibitory concentration: > 50000 nM
Compound 4 ended at the assay's limit; the forecaster's own chance of this, stated with the estimate: 60%; the middle value lies on the limit itself.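

Compound 2 and compound 4 both sit at a limit rather than a number, so no step between them can be read: the limit of > 50000 nM in this assay, at which 2 of the 4 values shown sit.

The compounds shown leave open whether 4-(trifluoromethyl)phenyl in place of 2-fluorophenyl shifts inhibition at all in this assay.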